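Ester series: methyl for trifluoromethyl on the aryl ring

The source may report more compounds than this note shows. Statements on the series, on what has been measured and on what is new or still open speak of the compounds shown alone.

Compound 3 `CC1=CC[C@H](C(C)C)c2cc(C)c(OC(=O)c3cccc(C(F)(F)F)c3)cc21` carries a trifluoromethyl on the aromatic ring of the ester. Within the data shown here, in a functional assay on HCT-15 cells (Homo sapiens) for antiproliferative activity, read by sulforhodamine B assay, with a stated time of 48 h, tested at 50 uM (a higher number here means more inhibition at the concentration tested (going by the name of the read-out), a lower number less inhibition), compound 3 gives 15%, the second highest of the three numbers so far; the nearest is compound 2 `CC1=CC[C@H](C(C)C)c2cc(C)c(OC(=O)c3cccc(Cl)c3)cc21` with 5.3%, the furthest compound 1 `CC1=CC[C@H](C(C)C)c2cc(C)c(OC(=O)c3ccc(C)cc3)cc21` with 78.9%. Compound 4 `CC1=CC[C@H](C(C)C)c2cc(C)c(OC(=O)c3cccc(C)c3)cc21` is the next member: methyl in place of trifluoromethyl on an aromatic carbon.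

Among the measured compounds shown here, two measured steps bear on it. The step of a number 73.6 percentage points lower from compound 1 to compound 2 (beyond the scatter) was large but changed both the group and its position, so it does not isolate the effect of the group alone. The step of a number 9.7 percentage points higher from compound 2 to compound 3 (within the scatter) shows that exchanging chloro for trifluoromethyl at this position leaves the number within the scatter. For the measured compounds named here, no measured pair shows methyl against trifluoromethyl at the same position, and only compound 1 holds a methyl on this ring at all, with a high number. The expected step of a number 15 percentage points higher from compound 3 to compound 4 (beyond the scatter) is therefore small to moderate upward, with wide uncertainty. Compound 4 is estimated at 30%, expected between 5% and 70%.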

Compound 4, a percentage reported as inhibition, at one concentration (the size of the read-out at that concentration, not a potency): 5.3%
Compound 4: middle estimate off by 24.7 percentage points, on the high side; the measured number falls inside the stated range.
By their numbers in this assay, from the lowest: compounds 2, 4 and 3 (each within the scatter of the next); then compound 1.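

In this assay, the steps of a number 9.7 percentage points lower from compound 3 to compound 4 (within the scatter) and no change at the digits printed from compound 2 to compound 4 (within the scatter) place methyl, chloro and trifluoromethyl on this aromatic carbon, meta to a large group, all within the scatter of one another, so these three groups do not separate the compounds here. The step of a number 73.6 percentage points lower from compound 1 to compound 4 (beyond the scatter) keeps a methyl on the ring and changes only its place, which separates place from group as the step between compound 1 and compound 2 could not: the high number of compound 1 goes with where its methyl sits, not with methyl as such. Nothing on hand accounts for this dependence on place.

On these data alone, only compound 1 holds a group at that other place, so whether the high number is specific to methyl there remains open. A chloro, an amine or a carboxylic acid at that place would test it.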